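This account rests on a few compounds, and the source may have more. Where it says the series, first, only, none or still open, it means among the compounds named here.

Compound 1 `CCOC(=O)C1=C(C(F)(F)F)NC(=O)NC1c1cccs1` was tested in an assay on HeLa cells for displacement of a labelled ligand from adenosine receptor A3 (Homo sapiens), read by radioligand binding, with a stated time of 180 min, tested at 1 uM (on this read-out higher numbers stand for more inhibition at the one concentration tested (going by the name of the read-out) and lower numbers for less inhibition), and gave 1%. Compound 2 `CC1=C(C(=O)OCC(F)(F)F)C(c2ccsc2)NC(=O)N1` gives 1% in this assay, level with compound 1 within the usual scatter. Compound 3 `CC(C)OC(=O)C1=C(C(F)(F)F)NC(=O)NC1c1cccs1` is not yet measured. It differs from compound 1 in one place: methyl in place of hydrogen on a saturated chain carbon bound to an oxygen next to a carbonyl group and a saturated chain carbon. Going by the values given here, no measured pair here shows such a step, so its effect is unknown. Since compound 1 shows 1%, compound 3 is expected to stay near that level, with an estimated step of a number 1 percentage points higher from compound 1 to compound 3 (within the scatter) not beyond the scatter. The estimate for compound 3 in this assay is 2%, between -8% and 12%.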

Compound 3, a percentage reported as inhibition, at one concentration (the size of the read-out at that concentration, not a potency): 7%
Estimate against measurement, compound 3: 5 percentage points below; the measured number falls inside the stated range.
By their numbers in this assay, from the lowest: compounds 1, 2 and 3 (each within the scatter of the next).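

In this assay, the first step read at this position, ethoxycarbonyl to isopropoxycarbonyl, gives a number 6 percentage points higher from compound 1 to compound 3 (within the scatter). Adding methyl on this saturated chain carbon therefore leaves the reading inside the usual scatter of repeated measurements, so this single change shows no real effect. No available data bear on the cause of this result.

The compounds shown leave open whether a longer chain, such as butyl, would move the reading beyond the scatter. They also leave open what a carboxylic acid or an amide would do in place of the ester.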